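Aryl swap on the cinnamamide arm of the benzophenone series

The source may report more compounds than this note shows. Statements on the series, on what has been measured and on what is new or still open speak of the compounds shown alone.

Measured so far:
- compound 1 `COc1ccc(C(=O)c2cc(OC)c(OC)c(OC)c2)cc1N`: 1100 nM
- compound 2 `COc1ccc(/C=C/C(=O)Nc2cc(C(=O)c3cc(OC)c(OC)c(OC)c3)ccc2OC)cc1`: 11100 nM
- compound 3 `C#CCOc1cccc(/C=C/C(=O)Nc2cc(C(=O)c3cc(OC)c(OC)c(OC)c3)ccc2OC)c1`: 13100 nM

All values come from a functional assay on PC-3 cells (Homo sapiens) for cytotoxicity, read by MTT assay, with a stated time of 72 h; a lower number here means a stronger inhibitor, a higher number a weaker inhibitor. Compound 3 gives the highest of the three numbers. Its nearest neighbour is compound 2, with a step of a 1.2-fold higher number from compound 2 to compound 3 (0.07 log units; within the scatter), so the two stand together within the scatter. Compound 1, the parent aniline, sits far lower and is the only one of the three beyond the scatter from compound 3.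

Compound 4 `COc1ccc(C(=O)c2cc(OC)c(OC)c(OC)c2)cc1NC(=O)/C=C/c1ccc(F)c(F)c1` is the next member. Relative to compound 3 the change is 3,4-difluorophenyl in place of 3-(propargyloxy)phenyl on a double-bonded chain carbon bound to a double-bonded chain carbon.

Within the data shown here, only one measured step bears on this: the exchange of one aryl group for another on the same double-bonded chain carbon, a 1.2-fold higher number from compound 2 to compound 3 (0.07 log units; within the scatter), which did not move the number beyond the scatter. Nothing measured separates a 3,4-difluorophenyl from the aryl groups already tried, so the expectation is that the number for compound 4 in this assay stays close to that of compound 3, with a step of a 1.2-fold lower number from compound 3 to compound 4 (0.08 log units; within the scatter) or none beyond the scatter. Compound 4 is therefore estimated at 11000 nM, within a range of 4000 nM to 30000 nM.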

Compound 4, half-maximal inhibitory concentration: 8300 nM
The estimate for compound 4 lay 1.3-fold (0.12 log units) above the measured number; low and high end bracket the measured number.
By their numbers in this assay, from the lowest: compound 1; then compounds 4, 2 and 3 (each within the scatter of the next).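

In this assay a third aryl group on this double-bonded chain carbon gives the same picture: a 1.6-fold lower number from compound 3 to compound 4 (0.20 log units; within the scatter) and a 1.3-fold lower number from compound 2 to compound 4 (0.13 log units; within the scatter) both leave the number where it was. The earlier compounds shown here showed this only for two oxygen-bearing aryl groups, whereas 3,4-difluorophenyl carries fluorine, has no hydrogen-bond acceptor and lacks the triple bond, and still the number does not move beyond the scatter, so across compound 2, compound 3 and compound 4 the identity of the aryl group has no readable effect. No measurement at hand accounts for this flat result.

Open, going by these compounds, is whether a basic amine or a carboxylic acid on the aryl ring, or a saturated ring in place of it, would shift the number. Also open, on these data alone, is whether any group on this arm brings the series close to compound 1 at 1100 nM in this assay.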